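Exchanging the Amine on the Thiocarbonyl Carbon

This account rests on a few compounds, and the source may have more. Where it says the series, first, only, none or still open, it means among the compounds named here.

Two compounds of this series have so far been examined in a functional assay on MGC-803 cells (Homo sapiens) for antiproliferative activity, read by CCK-8 assay, with a stated time of 72 h, tested at 2 uM; on this read-out lower numbers stand for a weaker effect and higher numbers for a stronger effect at the one concentration tested. Compound 1 `Nc1ccccc1NC(=O)c1ccc(CSC(=S)N2CCCc3ccccc32)cc1` gives 38.5% in this assay, and of the two numbers it is the higher one. Compound 2 `N#Cc1ccc(N2CCN(C(=S)SCc3ccc(C(=O)Nc4ccccc4N)cc3)CC2)cc1` gives 34.5% in this assay, a gap that lies within the usual scatter, so neither compound can be called the more active of the pair.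

Compound 3 `CN(Cc1cccnc1)C(=S)SCc1ccc(C(=O)Nc2ccccc2N)cc1` has not yet been measured. It differs from compound 1 in a single place: methyl((pyridin-3-yl)methyl)amino in place of 1,2,3,4-tetrahydroquinolin-1-yl on a thiocarbonyl carbon. Within the data shown here, no two measured compounds differ by this change, so there is no measured step to lean on. The step from compound 1 to compound 3 that is expected in this assay is a number 4.5 percentage points lower from compound 1 to compound 3 (within the scatter), that is, nothing beyond the scatter in either direction. Compound 3 is therefore estimated to give about 34% in this assay, with a range from 18% to 50%.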

Compound 3, a percentage reported as inhibition, at one concentration (the size of the read-out at that concentration, not a potency): 45.9%
For compound 3 the middle estimate is 11.9 percentage points below the measured one, and the stated range covers the measured number.
By their numbers in this assay, from the lowest: compounds 2, 1 and 3 (each within the scatter of the next, the first and the last beyond it).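

In this assay, the exchange of 1,2,3,4-tetrahydroquinolin-1-yl for methyl((pyridin-3-yl)methyl)amino on the thiocarbonyl carbon gives a number 7.4 percentage points higher from compound 1 to compound 3 (within the scatter). This position therefore accepts a group with one six-membered aromatic ring holding a hetero atom and no non-aromatic ring, in place of the two-ring group, with no change that can be told from the scatter at this single concentration. No measurement of any property of these groups is at hand to account for the step.

The compounds shown leave open whether the ring nitrogen of the pyridine or the methyl on the amine has any bearing on the read-out. A benzyl(methyl)amino group or a morpholin-4-yl group on the same carbon would speak to this, and a single concentration leaves potency itself open.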